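A few compounds are considered here, and "the series" means these few. Any claim that something is new, unique, unknown or untested is made for them only; others in the source may bear on it.

Working notes on the series. Compound 1 `COc1cc(C(=O)c2sc(-c3ccc(Cl)cc3)cc2N)cc(OC)c1OC` gives in a functional assay on FM3A cells (Mus musculus) for antiproliferative activity (a higher number here means a weaker inhibitor, a lower number a stronger inhibitor), a value of 90 nM. Compound 2 `COc1cc(C(=O)c2sc(-c3ccc(F)cc3)cc2N)cc(OC)c1OC` gives 16 nM in this assay, and compound 3 `COc1cc(C(=O)c2sc(-c3ccc(C(F)(F)F)cc3)cc2N)cc(OC)c1OC` gives 540 nM. Going by the values given here, of the three numbers so far, compound 1 stands second highest; the nearer gap is the step of a 5.6-fold lower number from compound 1 to compound 2 (0.75 log units; beyond the scatter), the wider one the step of a 6.0-fold higher number from compound 1 to compound 3 (0.78 log units; beyond the scatter). The two outer compounds are separated by the step of a 34-fold higher number from compound 2 to compound 3 (1.53 log units; beyond the scatter).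

Compound 4 `COc1cc(C(=O)c2sc(-c3ccc(Br)cc3)cc2N)cc(OC)c1OC` differs from compound 1 by bromo in place of chloro on an aromatic carbon, the change sitting on an aromatic carbon of a six-membered aromatic ring of carbon only, para to a large group. Among the compounds with values here, the steps that bear on this are those that swap the group at the same place: fluoro for chloro lowered the number in a 5.6-fold lower number from compound 1 to compound 2 (0.75 log units; beyond the scatter), and trifluoromethyl for chloro raised it in a 6.0-fold higher number from compound 1 to compound 3 (0.78 log units; beyond the scatter), so the smallest group gave the lowest number and the largest group the highest. Bromo lies between chloro and trifluoromethyl in this ordering, so in this assay a modest rise from compound 1 is expected, smaller than the step to compound 3, though a number within the scatter of compound 1 would not surprise. The step expected is a 1.8-fold higher number from compound 1 to compound 4 (0.25 log units; within the scatter). Compound 4 is therefore estimated at 160 nM, with a range from 55 nM to 480 nM.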

Compound 4, half-maximal inhibitory concentration: 150 nM
Estimate against measurement, compound 4: 1.1-fold (0.03 log units) above; the measured number falls inside the stated range.
By their numbers in this assay, from the lowest: compound 2; then compounds 1 and 4 (each within the scatter of the next); then compound 3.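

Bromo in place of chloro leaves the number within the scatter in this assay (a 1.7-fold higher number from compound 1 to compound 4 (0.22 log units; within the scatter)), so the 4-chlorophenyl and 4-bromophenyl compounds cannot be told apart here, which the earlier compounds could not show. Bromo nevertheless stays clearly separated from both other groups at this place, on one side by the step (a 9.4-fold higher number from compound 2 to compound 4 (0.97 log units; beyond the scatter)) and on the other by the step (a 3.6-fold lower number from compound 3 to compound 4 (0.56 log units; beyond the scatter)). The four compounds therefore fall into three levels rather than a steady ladder: fluoro lowest, chloro and bromo together, and trifluoromethyl highest, with none of the four going against this grouping. Nothing on hand gives a reason for these levels.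

All four groups shown are halogens or trifluoromethyl, so it remains open where a methyl, a methoxy, a nitrile or an amine at this place would fall relative to the three levels. Also open is whether the same levels would hold with these groups placed elsewhere on the six-membered aromatic ring, since every compound shown carries its group para to a large group.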